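One Chloro Fewer on the Shared Core

The source may hold more compounds than are shown below. What is called first, only, known or untested is meant among the compounds shown, and "the series" means these compounds.

Compound 2 `ClCc1ccccc1Cn1cnc2c(Cl)nc(Cl)nc21` stands highest of the two numbers at hand: in a functional assay on HCC 2998 cells (Homo sapiens) for cytotoxicity, read by sulforhodamine B assay, with a stated time of 48 h (on this read-out higher numbers stand for lower toxicity in this test and lower numbers for higher toxicity in this test), compound 2 gives 6160 nM, while compound 1 `ClCc1ccc(Cn2cnc3c(Cl)ncnc32)cc1` gives 5120 nM in this assay, a gap that lies within the usual scatter. Going by the values given here, no step between measured compounds is available. Compound 3 `ClCc1ccccc1Cn1cnc2c(Cl)ncnc21` differs from compound 2 by hydrogen in place of chloro on an aromatic carbon. With nothing to anchor the size of this change, no shift beyond the scatter is expected in this assay, in either direction. Compound 3 is estimated at 7000 nM, with a range from 3000 nM to 16000 nM. The expected step is a 1.1-fold higher number from compound 2 to compound 3 (0.06 log units; within the scatter).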

Compound 3, concentration lethal to 50% of the cells: 7410 nM
Compound 3: the middle estimate sits 1.1-fold (0.02 log units) below what was measured; low and high end bracket the measured number.
By their numbers in this assay, from the lowest: compounds 1, 2 and 3 (each within the scatter of the next).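

Hydrogen in place of chloro on this aromatic carbon, between two ring nitrogen atoms, gives a 1.2-fold higher number from compound 2 to compound 3 (0.08 log units; within the scatter) in this assay as the first step that changes a single place. At this position, then, the chloro group can give way to hydrogen without a shift beyond the scatter. No measurement at hand offers an explanation for this result. What the compounds shown leave open is whether an amine or a methoxy group on the same carbon would move the number beyond the scatter. Only chloro and hydrogen are compared there so far.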